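An Ester Group at the End of an Amine Chain

This account rests on a few compounds, and the source may have more. Where it says the series, first, only, none or still open, it means among the compounds named here.

Compound 1 `CCCN1CCC(CCCn2c(COc3ccc(Cl)cc3)nc3c(C)cccc32)CC1` was tested in an assay on AV12 cells for binding affinity to Neuropeptide Y receptor type 1 (Homo sapiens) (a higher number here means a weaker inhibitor, a lower number a stronger inhibitor), where compound 1 gives 29 nM. Among the three compounds measured, compound 1 stands second highest. Compound 2 `Cc1cccc2c1nc(COc1ccc(Cl)cc1)n2CCCC1CCN(CCC(C)C)CC1` gives 11 nM, and the change a 2.6-fold lower number from compound 1 to compound 2 (0.42 log units; beyond the scatter) is a modest gain. Compound 3 `Cc1cccc2c1nc(COc1ccc(Cl)cc1)n2CCCC1CCN(Cc2ccccc2)CC1` gives 109 nM, and the change a 3.8-fold higher number from compound 1 to compound 3 (0.58 log units; beyond the scatter) is a modest loss; between the two, a 9.9-fold higher number from compound 2 to compound 3 (1.00 log units; beyond the scatter). All three differ only in the group carried on the chain attached to the amine nitrogen in the ring, so all three bear on the new compound. Compound 4 `CCOC(=O)CCCN1CCC(CCCn2c(COc3ccc(Cl)cc3)nc3c(C)cccc32)CC1` differs from compound 1 by ethoxycarbonyl in place of hydrogen on a saturated chain carbon, three bonds along the chain from an amine nitrogen in a ring. For the measured compounds named here, in the measured steps a larger saturated group on this chain helped and a phenyl hurt, while no measured compound carries an ester or any hydrogen-bond acceptor on this chain. The expected step is therefore small, a 1.6-fold higher number from compound 1 to compound 4 (0.19 log units; within the scatter), leaning towards a weaker value. Compound 4 is expected to give 45 nM, within a range from 15 nM to 140 nM.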

Compound 4, inhibition constant: 29 nM
Compound 4: the middle estimate sits 1.6-fold (0.19 log units) above what was measured; measured number inside the range.
By their numbers in this assay, from the lowest: compound 2; then compounds 1 and 4 (each within the scatter of the next); then compound 3.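

In this assay, for the compounds shown here, ethoxycarbonyl in place of hydrogen on a saturated chain carbon, three bonds along the chain from an amine nitrogen in a ring, gives no measurable shift (no change at the digits printed from compound 1 to compound 4 (within the scatter)), so this position accepts a group with a carbonyl and two oxygens, whereas the earlier compounds carried only hydrocarbon groups here. The 3-(ethoxycarbonyl)propyl chain also compares well with the benzyl group (a 3.8-fold lower number from compound 3 to compound 4 (0.58 log units; beyond the scatter)), but it falls short of the isobutyl-bearing chain (a 2.6-fold higher number from compound 2 to compound 4 (0.42 log units; beyond the scatter)), so the ester matches the propyl chain rather than the best chain seen. Nothing available explains this tolerance.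

Going by these compounds, whether a carboxylic acid or an amide at the end of this chain would give a similar number remains open. So does the effect of a shorter or longer chain between the amine nitrogen and the ester.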